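Aryl swap on a series resting at the assay limit

The compounds below may be only part of what the source reports. "The series", "measured", "known", "first", "only" and "open" are said of these compounds alone.

Values in a functional assay on OVCAR-3 cells (Homo sapiens) for antiproliferative activity, read by spectrophotometry, with a stated time of 2 days (a lower number here means a stronger inhibitor of growth, a higher number a weaker inhibitor of growth), so far:
- compound 1 `COc1ccc(Nc2ncc(C(F)(F)F)c(N3Cc4cccc(N(C)S(C)(=O)=O)c4C3)n2)cc1C(F)(F)F` gives > 30000 nM as a limit
- compound 2 `COc1ccc(C(F)(F)F)cc1Nc1ncc(C(F)(F)F)c(N2Cc3cccc(N(C)S(C)(=O)=O)c3C2)n1` gives > 30000 nM as a limit

Compound 1 offers only a limit (> 30000 nM) and no number to start from. For the measured compounds named here, compound 3 `COc1cc(Nc2ncc(C(F)(F)F)c(N3Cc4cccc(N(C)S(C)(=O)=O)c4C3)n2)c(OC)cc1Cl` keeps the core of compound 1 and carries 4-chloro-2,5-dimethoxyphenyl in place of 4-methoxy-3-(trifluoromethyl)phenyl on a nitrogen on an aromatic ring as its one change. Going by the values given here, the only measured step at this place, a step that the two limits leave unreadable from compound 1 to compound 2, has no readable size. The evidence stops at the limit of > 30000 nM in this assay, at which 2 of the 2 values shown sit, and shows no gain so far. A step of no clear size or direction is therefore expected in this assay for this change. The estimate is a number no higher from compound 1 to compound 3 (the limit leaves the size open) as an expected outcome. Compound 3 is estimated at 30000 nM with an expected range from 10000 nM to 60000 nM and may well return only a limit.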

Compound 3, concentration for 50% growth inhibition: > 30000 nM
Compound 3 gave a limit, no number; the forecaster's own chance of this, stated with the estimate: 75%; the middle value lies on the limit itself.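

In this assay, for the compounds shown here, no step among compound 1, compound 2 and compound 3 can be read, as all three give only a limit: the limit of > 30000 nM in this assay, at which 3 of the 3 values shown sit.

Going by these compounds, whether any aryl group at this place on the shared core can bring a measurable growth inhibition remains open.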